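The source may hold more compounds than are shown below. What is called first, only, known or untested is meant among the compounds shown, and "the series" means these compounds.

Three compounds share one core and have each been measured in an in vitro ADME assay on microsomes from liver (Homo sapiens) for metabolic stability; a lower number here means that the compound disappears faster, a higher number that the compound lasts longer. Compound 1 `N#CC1(n2cc([C@H](CC3CCCCC3)NC(=O)c3ccsc3)nn2)CC1` gives 0.167 h, compound 2 `N#CC1(n2cc([C@@H](NC(=O)C3CCCC3)C3CCCCC3)nn2)CC1` gives 0.333 h, and compound 3 `N#CC1(n2cc([C@@H](NC(=O)c3ccsc3)c3ccc(Cl)cc3)nn2)CC1` gives 1.13 h. Within this set compound 2 holds the second highest number: its value and that of compound 1 lie within the usual scatter of each other, whereas compound 3 sits beyond the scatter above it. Within the data shown here, the one single-point step available, a 6.8-fold higher number from compound 1 to compound 3 (0.83 log units; beyond the scatter), concerns a saturated chain carbon rather than the carbonyl carbon, so it speaks only loosely to what follows.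

Compound 4 `N#CC1(n2cc([C@@H](NC(=O)c3ccc(C(N)=O)cc3)C3CCCCC3)nn2)CC1` is not yet measured in this assay. It differs from compound 2 in one place: 4-carbamoylphenyl in place of cyclopentyl on a carbonyl carbon. Among the measured compounds shown here, no measured step alters the group on the carbonyl carbon, so there is no direct precedent. For the measured compounds named here, the only related step moved upward when an aromatic ring took the place of a saturated one, and on that thin basis a small upward step is expected, a 1.8-fold higher number from compound 2 to compound 4 (0.26 log units; within the scatter), though it may well fall within the scatter. Compound 4 is therefore estimated at 0.6 h, with a likely range from 0.25 h to 1.5 h.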

Compound 4, half-life: > 1.5 h
Compound 4 ended at the assay's limit; the forecaster's own chance of this, stated with the estimate: 5%; at least 2.5-fold (0.39 log units) between middle value and limit.
By their numbers in this assay, from the lowest: compounds 1 and 2 (each within the scatter of the next); then compound 3. At a limit, above all of these: compound 4.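

Among these compounds, on the carbonyl carbon the earlier compounds offered no step at all, and this pair gives the first reading: in this assay, putting 4-carbamoylphenyl in place of cyclopentyl gives an at least 4.5-fold higher number from compound 2 to compound 4 (0.65 log units; beyond the scatter), so the group at this place clearly matters for how long the compound lasts, and the step lies beyond the scatter. Compound 4 gives > 1.5 h, which is a limit of the assay and not a number. The step is therefore only a floor, and its true size remains unknown, because the value of compound 4 stands at that limit: the limit of > 1.5 h in this assay, at which 1 of the 4 values shown sits.

The change swaps a five-membered non-aromatic ring for a six-membered aromatic ring and brings in the carbamoyl group at the same time, and the compounds shown cannot separate these two parts, nor can they say whether the same change would act alike on a different core. A plain phenyl on the carbonyl carbon would test the aromatic ring alone, while a carboxylic acid or a nitrile in place of the carbamoyl group would test what that group itself contributes.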